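Hydroxymethyl in Place of Ethoxycarbonyl on the Shared Core

A few compounds are considered here, and "the series" means these few. Any claim that something is new, unique, unknown or untested is made for them only; others in the source may bear on it.

Compound 1 `CCOC(=O)[C@@]1(C(=O)NCc2ccc(C)cc2)C[C@H]1c1cc(OC)c(OC)c(OC)c1` carries an ethoxycarbonyl group on the small ring. In a functional assay on SW480 cells (Homo sapiens) for cytotoxicity, read by MTT assay, with a stated time of 48 h (on this read-out lower numbers stand for stronger inhibition and higher numbers for weaker inhibition), compound 1 reaches only a limit of the assay, > 100000 nM. Compound 2 `COc1cc([C@@H]2C[C@@]2(CO)C(=O)NCc2ccc(C)cc2)cc(OC)c1OC` differs by hydroxymethyl in place of ethoxycarbonyl on a saturated ring carbon, and in this assay compound 2 gives 76300 nM. That change made a step of an at least 1.3-fold lower number from compound 1 to compound 2 (0.11 log units; that floor lies within the scatter). Compound 3 `CCOC(=O)[C@@]1(C(=O)NCc2ccc(C)cc2)C[C@@H]1c1cc(OC)c(OC)c(OC)c1` differs from compound 1 by the two compounds have the same atoms and bonds and differ only in configuration as drawn: 1 of 2 stereo elements differ; a stereocentre at a saturated ring carbon is drawn S in compound 1 and R in compound 3. In this assay compound 3 also reaches only a limit, > 100000 nM. The step that the two limits leave unreadable from compound 1 to compound 3 therefore cannot be read.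

Compound 4 `COc1cc([C@H]2C[C@@]2(CO)C(=O)NCc2ccc(C)cc2)cc(OC)c1OC` has not been measured; it differs from compound 3 by hydroxymethyl in place of ethoxycarbonyl on a saturated ring carbon, the same change seen once before. Compound 4 is expected near 80000 nM, between 30000 nM and 200000 nM. This expected step of an at least 1.2-fold lower number from compound 3 to compound 4 (0.09 log units; that floor lies within the scatter) rests on the earlier step of an at least 1.3-fold lower number from compound 1 to compound 2 (0.11 log units; that floor lies within the scatter), which stayed within the scatter.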

Compound 4, half-maximal inhibitory concentration: > 100000 nM
Compound 4 was reported as a limit (the forecaster's own chance of this, stated with the estimate: 40%); middle value at least 1.2-fold (0.09 log units) from the limit.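

In this assay compound 4 reaches only a limit, > 100000 nM. Within the data shown here, compound 3 is also a limit, so hydroxymethyl in place of ethoxycarbonyl cannot be read on this core, and neither this step nor the one between compounds 1 and 3 can be sized, because the values at both ends are limits: the limit of > 100000 nM in this assay, at which 3 of the 4 values shown sit. The result therefore shows neither that the change carries over from the core of compound 1 nor that it fails to, and the two hydroxymethyl compounds, which differ only in configuration as drawn, show an at least 1.3-fold higher number from compound 2 to compound 4 (0.11 log units; that floor lies within the scatter).

The compounds shown leave open how far compounds 1, 3 and 4 lie from their limits. They also leave open whether an amine, a carboxylic acid or a longer chain at this ring carbon would give a number that can be read in this assay.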